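This account rests on a few compounds, and the source may have more. Where it says the series, first, only, none or still open, it means among the compounds named here.

Of the compounds shown here, three have so far been measured in a functional assay on Huh-7 cells (Homo sapiens) for cytotoxicity, read by CCK-8 assay, with a stated time of 72 h; on this read-out lower numbers stand for stronger inhibition and higher numbers for weaker inhibition. Compound 1 `COc1ccccc1/C=c1/[nH]c(=O)/c(=C\c2cccc(Cl)c2Cl)[nH]c1=O` is reported as "not active" (no number reported). Compound 2 `C=CCn1c(=O)/c(=C\c2cccc(Cl)c2Cl)[nH]c(=O)/c1=C\c1ccccc1OC` gives 1200 nM, the highest of the two numbers available, and compound 3 `COc1ccccc1/C=c1\c(=O)[nH]/c(=C/c2cccc(Cl)c2Cl)c(=O)n1C` gives 300 nM. For the measured compounds named here, the only measured step, a 4.0-fold lower number from compound 2 to compound 3 (0.60 log units; beyond the scatter), follows from hydrogen in place of vinyl on a saturated chain carbon bound to an aromatic nitrogen. Compound 4 `C=CCn1c(=O)/c(=C\c2ccccc2F)[nH]c(=O)/c1=C\c1ccccc1OC` differs from compound 2 elsewhere: 2-fluorophenyl in place of 2,3-dichlorophenyl on a double-bonded chain carbon bound to an aromatic carbon. Going by the values given here, no measured step touches this change, so the data give no direction for it. Compound 4 is therefore estimated at 2500 nM in this assay, between 500 nM and 12000 nM. The expected step of a 2.1-fold higher number from compound 2 to compound 4 (0.32 log units; beyond the scatter) is thus small and uncertain in sign.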

Compound 4, half-maximal inhibitory concentration: 31300 nM
Compound 4: the middle estimate sits 13-fold (1.10 log units) below what was measured, outside the stated range (above it).
By their numbers in this assay, from the lowest: compound 3; then compound 2; then compound 4.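

In this assay, the exchange of 2,3-dichlorophenyl for 2-fluorophenyl on a double-bonded chain carbon bound to an aromatic carbon gives a 26-fold higher number from compound 2 to compound 4 (1.42 log units; beyond the scatter) and is a large step. For the compounds shown here, the earlier measured step concerned only the group on the aromatic nitrogen, so this is the first sign that this other place also strongly affects the read-out. No available evidence explains the size of this step.

The compounds shown leave open whether the fluorine or the loss of both chlorines drives the change, which a plain phenyl group here could help separate. On these data alone, whether the same exchange has a similar effect on compound 3 also remains open.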